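Compound 2 to compound 3: cytotoxicity working notes

The compounds below may be only part of what the source reports. "The series", "measured", "known", "first", "only" and "open" are said of these compounds alone.

In a toxicity assay on NIH3T3 cells (Mus musculus) for cytotoxicity, read by resazurin assay (on this read-out higher numbers stand for an effect only at larger amounts of compound and lower numbers for an effect already at smaller amounts), compound 1 `COC(=O)c1ccc(NCc2cncn2Cc2ccccc2OC)cc1-c1ccccc1` stands at "not determined" (no result reported) and so offers no reference. Compound 2 `COC(=O)c1ccc(NCc2cncn2Cc2cccc(C(C)(C)C)c2)cc1-c1ccccc1` gives > 1000 nM as its reading, which is a limit and not a number. Going by the values given here, the series therefore holds no single number so far. Compound 3 `COC(=O)c1ccc(NCc2cncn2Cc2ccc(C#N)cc2)cc1-c1ccccc1` carries 4-cyanophenyl in place of 3-(tert-butyl)phenyl on a saturated chain carbon bound to an aromatic nitrogen and is still to be measured. Among the compounds with values here, no measured step bears on this change. The expectation rests on compound 2 alone, with the limit of > 1000 nM in this assay, at which 1 of the 2 values shown sits, as its only anchor. An estimated step that the limit leaves unreadable from compound 2 to compound 3 is expected to stay within the scatter of this assay and to show no clear direction. For compound 3 the expected value is 1500 nM with an estimated range from 500 nM to 8000 nM and a good chance of another limit.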

Compound 3, half-maximal effective concentration: > 10000 nM
Compound 3 ended at the assay's limit; the forecaster's own chance of this, stated with the estimate: 65%; middle value at least 6.6-fold (0.82 log units) from the limit.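

In this assay, going by these compounds alone, compound 2 and compound 3 both read as limits and not as numbers, and no step between them can be read. The compounds shown leave open at what concentration either one acts, and whether 4-cyanophenyl in place of 3-(tert-butyl)phenyl shifts that concentration.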